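Adding a fluoro to the one measured compound

The source may report more compounds than this note shows. Statements on the series, on what has been measured and on what is new or still open speak of the compounds shown alone.

Measured so far in an ADME assay on J774 cells (Mus musculus) for cytotoxicity (a lower number here means that less compound is needed, a higher number that more compound is needed for the effect), as follows
compound 1 `Cc1[nH]c2ccccc2c(=O)c1Br` gives > 42000 nM as a limit
compound 2 `Cc1[nH]c2ccc(F)cc2c(=O)c1Br` gives > 39100 nM as a limit
compound 3 `CCCCC#Cc1c(C)[nH]c2ccccc2c1=O` gives 8900 nM as a number

Within the data shown here, compound 3 holds the only true number of the three, and the other two values are limits of the assay. Compound 4 `CCCCC#Cc1c(C)[nH]c2ccc(F)cc2c1=O` differs from compound 3 by one small change, fluoro in place of hydrogen on an aromatic carbon in short, fluoro in place of hydrogen on an aromatic carbon. Among the measured compounds shown here, the only measured pair with this same change gives a step that the two limits leave unreadable from compound 1 to compound 2 and so offers no size to carry over. The other measured step, an at least 4.7-fold lower number from compound 1 to compound 3 (0.67 log units; beyond the scatter) in this set, concerns the hex-1-yn-1-yl chain, which compound 4 keeps, so compound 4 is expected to give a number and not a limit. No step beyond the scatter is expected in this assay for this change, in either direction. The estimate amounts to a 1.1-fold lower number from compound 3 to compound 4 (0.05 log units; within the scatter) and no more. Compound 4 is expected at 8000 nM (estimated range 3500 nM to 18000 nM) when it is measured.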

Compound 4, half-maximal effective concentration: > 38600 nM
Compound 4 ended at the assay's limit; the forecaster's own chance of this, stated with the estimate: 10%; at least 4.8-fold (0.68 log units) between middle value and limit.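

In this assay, fluoro in place of hydrogen on this aromatic carbon gives an at least 4.3-fold higher number from compound 3 to compound 4 (0.63 log units; beyond the scatter), so this small change has a size that can be read once the hex-1-yn-1-yl chain is present. Keeping that chain is therefore not enough on its own to give a number, since compound 4 carries the chain and still reaches no true number in this assay. The reading for compound 4 is a limit and not a number: the limit of > 38600 nM in this assay, at which 1 of the 4 values shown sits.

From the compounds shown here alone, the steps that join two limits cannot be read, so it stays open whether fluoro has any effect on the bromo compounds. Also open, going by these compounds, is whether a chloro or methoxy group on the same aromatic carbon would behave like fluoro, and whether a longer chain would keep the effect seen with compound 3.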